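The source may report more compounds than this note shows. Statements on the series, on what has been measured and on what is new or still open speak of the compounds shown alone.

Of the compounds shown here, three have so far been measured in an assay on A10 cells for binding affinity to Endothelin-1 receptor (Rattus norvegicus); a higher number here means a weaker inhibitor, a lower number a stronger inhibitor. Compound 1 `Cc1ccccc1C(CCC(=O)O)C(=O)c1cccc(OCc2ccsc2)c1` gives 110 nM. Compound 2 `CC(=O)c1ccc(OCc2ccsc2)cc1OC(CCC(=O)O)c1ccccc1C` gives 26 nM, and compound 3 `Cc1ccccc1C(CCC(=O)O)Oc1cc(OCc2ccsc2)ccc1C(N)=O` gives 29 nM. For the measured compounds named here, compound 3 thus stands second highest of the three numbers: its nearest neighbour is compound 2, and the only single-point step measured, a 1.1-fold higher number from compound 2 to compound 3 (0.05 log units; within the scatter), lies within the scatter, while compound 1 sits clearly higher than compound 3.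

Compound 4 `Cc1ccccc1C(CCC(=O)O)Oc1cc(OCc2ccsc2)ccc1-c1ncc[nH]1` differs from compound 3 in one place: 1H-imidazol-2-yl in place of carbamoyl on an aromatic carbon. The carbamoyl that leaves is the very group that entered in the step from compound 2 to compound 3, and that step was within the scatter, which suggests the group at this aromatic carbon has so far tolerated change. Going by the values given here, no measured step replaces such a group with an aromatic ring, so the size of the coming step cannot be read from the data with any confidence. Compound 4 is therefore expected at 30 nM, with a range from 8 nM to 120 nM, meaning an expected step of a 1.0-fold higher number from compound 3 to compound 4 (0.01 log units; within the scatter) that may well stay within the scatter.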

Compound 4, half-maximal inhibitory concentration: 163000 nM
The estimate for compound 4 lay 5400-fold (3.74 log units) below the measured number; the measured number lies above the stated range.
By their numbers in this assay, from the lowest: compounds 2 and 3 (each within the scatter of the next); then compound 1; then compound 4.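

For the compounds shown here, this aromatic carbon, para to a (thiophen-3-yl)methoxy group, is far less forgiving than the earlier compounds suggested: in this assay, putting 1H-imidazol-2-yl in place of carbamoyl gives a 5600-fold higher number from compound 3 to compound 4 (3.75 log units; beyond the scatter), and putting it in place of acetyl gives a 6300-fold higher number from compound 2 to compound 4 (3.80 log units; beyond the scatter). Acetyl and carbamoyl are interchangeable here, but the counts show that keeping one hydrogen-bond donor and one hydrogen-bond acceptor, as carbamoyl and 1H-imidazol-2-yl both have, does not preserve the number. Nothing available explains why this change costs so much.

The compounds shown cannot separate the effect of the aromatic ring from that of the larger group, as both arrive together. As far as these compounds go, whether a nitrile, a carboxylic acid or an oxazol-2-yl ring at this carbon would match compound 3 or compound 4 remains open.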